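Ethynyl replacing 1-benzofuran-2-yl: working notes toward compound 4

This account rests on a few compounds, and the source may have more. Where it says the series, first, only, none or still open, it means among the compounds named here.

Measured so far in a functional assay on A549 cells (Homo sapiens), read by MTT assay, with a stated time of 72 h; a lower number here means a stronger inhibitor, a higher number a weaker inhibitor:
compound 1, `CNc1ncnc2c1c(-c1ccccc1)cn2[C@@H]1O[C@H](CO)[C@@H](O)[C@H]1O`, gives a limit of > 20000 nM.
compound 2, `C#Cc1cn([C@@H]2O[C@H](CO)[C@@H](O)[C@H]2O)c2ncnc(N(C)C)c12`, gives 390 nM.
compound 3, `CNc1ncnc2c1c(-c1cc3ccccc3o1)cn2[C@@H]1O[C@H](CO)[C@@H](O)[C@H]1O`, gives a limit of > 20000 nM.

Compound 3 stands only at a limit in this assay; it shares this with compound 1, as the limit of > 20000 nM in this assay, at which 2 of the 3 values shown sit, records. Within the data shown here, the one step available, a step that the two limits leave unreadable from compound 1 to compound 3, is therefore unreadable, both ends being limits.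

The next compound is compound 4, `C#Cc1cn([C@@H]2O[C@H](CO)[C@@H](O)[C@H]2O)c2ncnc(NC)c12`, differing from compound 3 as ethynyl in place of 1-benzofuran-2-yl on an aromatic carbon. Among the measured compounds shown here, no measured step covers this change directly. What the numbers do show is that compound 2, which carries the same ethynyl group and a dimethylamino group where compound 4 carries methylamino, sits well inside the measurable range, whereas both compounds bearing an aryl group at that carbon sit at the limit.

On that basis compound 4 is expected to leave the limit, with the step of an at least 33-fold lower number from compound 3 to compound 4 (1.52 log units; beyond the scatter) estimated as a gain in potency. The expected value for compound 4 in this assay is 600 nM, within 120 nM to 6000 nM.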

Compound 4, half-maximal inhibitory concentration: > 20000 nM
Compound 4: a limit, no number (the forecaster's own chance of this, stated with the estimate: 15%); middle value at least 33-fold (1.52 log units) from the limit.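

In this assay compound 4 gives > 20000 nM, which is a limit, so the ethynyl group on this aromatic carbon does not carry the series out of the limit when paired with methylamino, and the steps among compound 1, compound 3 and compound 4 cannot be read. Among these compounds, the one readable step lies on the nitrogen rather than at the aromatic carbon: hydrogen in place of methyl on a nitrogen on an aromatic ring gives an at least 51-fold higher number from compound 2 to compound 4 (1.70 log units; beyond the scatter). Most of the set now stands at one limit: the limit of > 20000 nM in this assay, at which 3 of the 4 values shown sit.

Going by these compounds, whether dimethylamino would also give a measurable value with phenyl or 1-benzofuran-2-yl on this carbon remains open. Also open, on these data alone, is how an ethyl group or a longer chain on that nitrogen would read in this assay.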